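Benzylic aryl group on the triazole: compound 3 to compound 4

The source may hold more compounds than are shown below. What is called first, only, known or untested is meant among the compounds shown, and "the series" means these compounds.

Working notes on the series. In a functional assay on RAW264.7 cells (Mus musculus) for inhibition, read by Griess assay, with stated times of 2 h and 24 h (a higher number here means a weaker inhibitor, a lower number a stronger inhibitor), compound 3 `COc1ccc([C@@H]2CC(=O)c3c(O)cc(OCc4cn(C)nn4)cc3O2)cc1O` gives 15200 nM, the highest of the three numbers recorded so far. Within the data shown here, compound 1 `COc1ccc([C@@H]2CC(=O)c3c(O)cc(OCc4cn(Cc5ccccc5C#N)nn4)cc3O2)cc1O` gives 14600 nM, within the scatter of compound 3, and compound 2 `COc1ccc([C@@H]2CC(=O)c3c(O)cc(OCc4cn(Cc5ccccc5Cl)nn4)cc3O2)cc1O` gives 6140 nM, the only value beyond it. Compound 4 `COc1ccc([C@@H]2CC(=O)c3c(O)cc(OCc4cn(Cc5cccc(C)c5)nn4)cc3O2)cc1O` carries 3-methylphenyl in place of hydrogen on a saturated chain carbon bound to an aromatic nitrogen. Among the measured compounds shown here, the steps that bear on this change run the other way: a 2.5-fold higher number from compound 2 to compound 3 (0.39 log units; beyond the scatter), whereas a 1.0-fold higher number from compound 1 to compound 3 (0.02 log units; within the scatter), and between the two aryl groups themselves a 2.4-fold lower number from compound 1 to compound 2 (0.38 log units; beyond the scatter). On compounds 1 and 2, an aromatic ring on that carbon thus gives at most a modest lowering of the number. For compound 4 a modest lowering is expected, a 1.8-fold lower number from compound 3 to compound 4 (0.25 log units; within the scatter), with an estimated value of 8500 nM and a range from 4000 nM to 17000 nM.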

Compound 4, half-maximal inhibitory concentration: 17400 nM
The estimate for compound 4 lay 2.0-fold (0.31 log units) below the measured number, outside the stated range (above it).
By their numbers in this assay, from the lowest: compound 2; then compounds 1, 3 and 4 (each within the scatter of the next).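

In this assay, 3-methylphenyl on this saturated chain carbon bound to an aromatic nitrogen cannot be told apart from hydrogen, with a 1.1-fold higher number from compound 3 to compound 4 (0.06 log units; within the scatter). It also cannot be told apart from 2-cyanophenyl, with a 1.2-fold higher number from compound 1 to compound 4 (0.08 log units; within the scatter), but it does differ from 2-chlorophenyl, with a 2.8-fold higher number from compound 2 to compound 4 (0.45 log units; beyond the scatter). An aromatic ring on that carbon therefore does not by itself lower the number, and only compound 2 stands apart; no measurement shown offers an explanation for this.

Still open, from the compounds shown here alone, is whether the chloro group alone sets compound 2 apart, and how an amine or a carboxylic acid on that ring would read.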